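Dienyl for phenyl on the longer amide chain

The source may hold more compounds than are shown below. What is called first, only, known or untested is meant among the compounds shown, and "the series" means these compounds.

Compound 1 `CCCCCCCCCCCCNC(=O)[C@@H](NC(=O)/C=C/c1ccccc1)[C@@H](C)O` was tested in a functional assay on MCF7 cells (Homo sapiens) for cytotoxicity, read by MTT assay, with a stated time of 48 h; a higher number here means a weaker inhibitor, a lower number a stronger inhibitor. In that test compound 1 gives only a limit, > 200000 nM. Compound 2 `C/C=C/C=C/C(=O)N[C@H](C(=O)NCCCCCCCCCCCC)[C@@H](C)O` differs from it by prop-1-en-1-yl in place of phenyl on a double-bonded chain carbon bound to a double-bonded chain carbon and gives 37100 nM; the step is an at least 5.3-fold lower number from compound 1 to compound 2 (0.73 log units; beyond the scatter). Compound 3 `CCCCCCCCCCCCCCCCCCNC(=O)[C@@H](NC(=O)/C=C/c1ccccc1)[C@@H](C)O` carries a different change, (hexyl in place of hydrogen on a saturated chain carbon, ten or more bonds along the chain from an amide-type nitrogen), and gives 39200 nM, so the step is an at least 5.1-fold lower number from compound 1 to compound 3 (0.70 log units; beyond the scatter). The values of compound 2 and compound 3 lie within the usual scatter of each other. Compound 4 `C/C=C/C=C/C(=O)N[C@H](C(=O)NCCCCCCCCCCCCCCCCCC)[C@@H](C)O` has not been measured. It differs from compound 3 by prop-1-en-1-yl in place of phenyl on a double-bonded chain carbon bound to a double-bonded chain carbon, the same change at the same place as between compound 1 and compound 2, while the two cores differ as already described for compound 3. Since compound 1 sits at the limit of > 200000 nM in this assay, at which 1 of the 3 values shown sits, the earlier step is only a lower bound, and the step to compound 4 is expected to be a 3.3-fold lower number from compound 3 to compound 4 (0.51 log units; beyond the scatter). Compound 4 is expected to give about 12000 nM in this assay, estimated between 3000 nM and 40000 nM.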

Compound 4, half-maximal inhibitory concentration: 79600 nM
The estimate for compound 4 lay 6.6-fold (0.82 log units) below the measured number; the measured number lies above the stated range.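

In this assay, putting prop-1-en-1-yl in place of phenyl on the core with the longer amide chain gives a 2.0-fold higher number from compound 3 to compound 4 (0.31 log units; beyond the scatter), so this change does not carry over from the shorter-chain core: the same change on two cores in this assay, an at least 5.3-fold lower number (0.73 log units; beyond the scatter) from compound 1 to compound 2 and a 2.0-fold higher number (0.31 log units; beyond the scatter) from compound 3 to compound 4, at least 10-fold (1.03 log units) apart, beyond the scatter of two such steps

Adding hexyl in place of hydrogen on the chain likewise depends on the core, giving a 2.1-fold higher number from compound 2 to compound 4 (0.33 log units; beyond the scatter): the same change on two cores in this assay, an at least 5.1-fold lower number (0.70 log units; beyond the scatter) from compound 1 to compound 3 and a 2.1-fold higher number (0.33 log units; beyond the scatter) from compound 2 to compound 4, at least 10-fold (1.03 log units) apart, beyond the scatter of two such steps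

The value of compound 1 is a limit, so the earlier steps are bounds, and these values do not show why the two cores respond differently: the limit of > 200000 nM in this assay, at which 1 of the 4 values shown sits.

The compounds shown leave open what a longer chain would give on either core. They also leave open whether an amine or a carboxylic acid on that chain would follow the same pattern.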